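Plasma stability of a benzoxazolone urea series in mouse

The source may hold more compounds than are shown below. What is called first, only, known or untested is meant among the compounds shown, and "the series" means these compounds.

Compound 1 `CC(C)N1CCC(c2ccc3c(c2)oc(=O)n3C(=O)NCCCCc2ccccc2)CC1` was examined in an ADME assay on a cell-free system (plasma, Mus musculus) for metabolic stability, read by LC-MS, tested at 2 uM (on this read-out higher numbers stand for a longer-lived compound and lower numbers for a shorter-lived compound), where compound 1 gives 0.667 h. Compound 2 `CN1CCC(c2cc3oc(=O)n(C(=O)NCCCCc4ccccc4)c3cc2F)CC1` gives 0.333 h in this assay, and the two numbers lie within the usual scatter of each other, so nothing separates them. Compound 3 `CN1CCN(c2ccc3c(c2)oc(=O)n3C(=O)NCCCCc2ccccc2)CC1=O` has not been measured. It differs from compound 1 by one change: 4-methyl-3-oxopiperazin-1-yl in place of 1-isopropylpiperidin-4-yl on an aromatic carbon. Within the data shown here, since no measured pair shows what this kind of change does, compound 3 is expected to stay near compound 1, with a step of a 1.3-fold lower number from compound 1 to compound 3 (0.13 log units; within the scatter) that is not beyond the scatter. Compound 3 is estimated at 0.5 h, within 0.2 h to 1.5 h.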

Compound 3, half-life: 0.333 h
Compound 3: middle estimate off by 1.5-fold (0.18 log units), on the high side, within the range that was stated.
By their numbers in this assay, from the lowest: compounds 2, 3 and 1 (each within the scatter of the next).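

Among these compounds, exchanging 1-isopropylpiperidin-4-yl for 4-methyl-3-oxopiperazin-1-yl on this aromatic carbon gives the first reading of this position in this assay, with a 2.0-fold lower number from compound 1 to compound 3 (0.30 log units; within the scatter). The position thus accepts a ring with a carbonyl and a second ring nitrogen without a step beyond the scatter. Nothing at hand accounts for the size of this step.

As far as these compounds go, whether a plain 4-methylpiperazin-1-yl would read differently from the oxopiperazine remains open, leaving the carbonyl and the second ring nitrogen unseparated. Also open, from the compounds shown here alone, is whether an open-chain dimethylamino group or a carboxylic acid here would give a step beyond the scatter.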